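This account rests on a few compounds, and the source may have more. Where it says the series, first, only, none or still open, it means among the compounds named here.

Measured so far in a functional assay on MCF7 cells (Homo sapiens) for cytotoxicity, read by MTT assay, with a stated time of 24 h; a lower number here means a stronger inhibitor, a higher number a weaker inhibitor:
Compound 1 `COc1ccc(N(CC(=O)NCCCSc2ccccc2)C(=O)CCSC2=C(C)C(=O)c3ccccc3C2=O)cc1` gives 16000 nM.
Compound 2 `O=C(COC(=O)/C=C/c1ccccc1)NCCC[Te]c1ccccc1` gives 1000 nM.
Compound 3 `COc1ccc(N(CC(=O)NCCCSc2ccccc2)C(=O)/C=C/c2ccccc2)cc1` gives >= 100000 nM.

Compound 3 stands at the edge of the measured numbers: its entry is a limit of this assay and not a number, which is what the limit of >= 100000 nM in this assay, at which 1 of the 3 values shown sits, records. Compound 4 `COc1ccc(N(CC(=O)NCCCSc2ccccc2)C(=O)C#Cc2ccccc2)cc1` differs from compound 3 by 2-phenylethynyl in place of 2-phenylethenyl on a carbonyl carbon. For the measured compounds named here, no step between two measured compounds covers this kind of change, so there is nothing to gauge its size against. The expectation is a step of a number no higher from compound 3 to compound 4 (the limit leaves the size open), no change beyond the scatter. Compound 4 is therefore estimated at 100000 nM, within a range from 30000 nM to 300000 nM, and it is expected that this assay will again report only a limit for it.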

Compound 4, half-maximal inhibitory concentration: >= 100000 nM
Compound 4 gave a limit, no number; the forecaster's own chance of this, stated with the estimate: 65%; the middle value sits exactly at the limit.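

No step can be read from compound 3 to compound 4, since both entries are limits and not numbers: the limit of >= 100000 nM in this assay, at which 2 of the 4 values shown sit.

The compounds shown leave open whether 2-phenylethynyl in place of 2-phenylethenyl on a carbonyl carbon changes the strength of inhibition at all.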